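This account rests on a few compounds, and the source may have more. Where it says the series, first, only, none or still open, it means among the compounds named here.

Compound 1 `CC(=O)NC1CCC(CN2CCN(c3cc(=O)c4cc(C(F)(F)F)cc([N+](=O)[O-])c4s3)CC2)CC1` carries an acetamido group on a saturated ring carbon of the shared core. In an ADME assay on Vero cells (Chlorocebus sabaeus) for cytotoxicity, read by MTT assay, with a stated time of 48 h (a lower number here means a stronger inhibitor, a higher number a weaker inhibitor), compound 1 gives > 64 ug/mL, which is a limit of the assay rather than a number. Compound 2 `O=c1cc(N2CCN(CC3CCC(OS(=O)(=O)c4ccccc4)CC3)CC2)sc2c([N+](=O)[O-])cc(C(F)(F)F)cc12` has (phenylsulfonyl)oxy in that place. In this assay compound 2 gives > 64 ug/mL, again a limit of the assay. Compound 3 `O=C(NC1CCC(CN2CCN(c3cc(=O)c4cc(C(F)(F)F)cc([N+](=O)[O-])c4s3)CC2)CC1)c1ccccc1` carries benzamido there, and in this assay compound 3 gives 44.3 ug/mL. Among these values compound 1 stands at the limit of > 64 ug/mL in this assay, at which 2 of the 3 values shown sit, so its exact number is not known. The step that the two limits leave unreadable from compound 1 to compound 2 therefore cannot be read, while an at least 1.4-fold lower number from compound 1 to compound 3 (0.15 log units; that floor lies within the scatter) and an at least 1.4-fold lower number from compound 2 to compound 3 (0.15 log units; that floor lies within the scatter) are both small steps toward a lower number.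

Compound 4 `COc1cccc(C(=O)OC2CCC(CN3CCN(c4cc(=O)c5cc(C(F)(F)F)cc([N+](=O)[O-])c5s4)CC3)CC2)c1` is not yet measured. It differs from compound 1 as follows: ((3-methoxyphenyl)carbonyl)oxy in place of acetamido on a saturated ring carbon. The two steps that bear on it, an at least 1.4-fold lower number from compound 1 to compound 3 (0.15 log units; that floor lies within the scatter) and an at least 1.4-fold lower number from compound 2 to compound 3 (0.15 log units; that floor lies within the scatter), each move the number only a little lower, within the scatter. A similar outcome is expected here: an at least 1.2-fold lower number from compound 1 to compound 4 (0.10 log units; that floor lies within the scatter), or no change beyond the scatter. Compound 4 is therefore estimated at 50 ug/mL in this assay, with a range from 25 ug/mL to 100 ug/mL, and a fair chance that only a limit is reported again.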

Compound 4, half-maximal inhibitory concentration: > 64 ug/mL
Compound 4 gave a limit, no number; the forecaster's own chance of this, stated with the estimate: 50%; at least 1.2-fold (0.10 log units) between middle value and limit.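

Replacing acetamido with ((3-methoxyphenyl)carbonyl)oxy puts a larger group on this saturated ring carbon, one with an aromatic ring and no hydrogen-bond donor, and the result in this assay is still a limit of the assay rather than a number. Going by these compounds alone, the one step that can be read is an at least 1.4-fold higher number from compound 3 to compound 4 (0.15 log units; that floor lies within the scatter), so exchanging benzamido for this group does not clearly separate the two compounds. The steps to compound 4 from compound 1 and from compound 2 cannot be read, and compound 3 remains the only compound with an exact number: the limit of > 64 ug/mL in this assay, at which 3 of the 4 values shown sit.

From the compounds shown here alone, how far compound 1, compound 2 and compound 4 truly lie from compound 3 stays unknown, and so does any order among those three. Also open, going by these compounds, is what an amine, a carboxylic acid or a longer chain on this saturated ring carbon would give in this assay, and whether any of these would bring the number clearly down.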